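The compounds below may be only part of what the source reports. "The series", "measured", "known", "first", "only" and "open" are said of these compounds alone.

The set opens with compound 1 `O=C(Nc1ccccc1)C(Cl)Cl`, for which the entry in a functional assay on Bel-7402 cells (Homo sapiens) for antiproliferative activity, read by MTT assay, with a stated time of 72 h (on this read-out lower numbers stand for stronger inhibition and higher numbers for weaker inhibition), reads "not determined" (no result reported), and compound 2 `Cc1cccc(NC(=O)C(Cl)Cl)c1`, for which the entry in this assay reads "not determined" (no result reported). Among the compounds with values here, compound 3 `O=C(Nc1cccc(Cl)c1)C(Cl)Cl` therefore carries the only number: in this assay compound 3 gives 44500 nM, which places it as the single reference point, with nothing to rank it against. Compound 4 `O=C(Nc1cccc(Br)c1)C(Cl)Cl` differs from compound 3 by bromo in place of chloro on an aromatic carbon. Within the data shown here, no comparable step between measured compounds exists here, so the size of the change can only be guessed; the exchange of one halogen for another of the same count is expected to move this assay by no more than the usual scatter, in no particular direction, with the step from compound 3 to compound 4 estimated at a 1.1-fold lower number from compound 3 to compound 4 (0.05 log units; within the scatter). On that basis compound 4 is expected to give about 40000 nM in this assay, most likely between 15000 nM and 110000 nM.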

Compound 4, half-maximal inhibitory concentration: 7720 nM
For compound 4 the middle estimate is 5.2-fold (0.71 log units) above the measured one, and the stated range ends above it.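

In this assay bromo in place of chloro on this aromatic carbon gives a 5.8-fold lower number from compound 3 to compound 4 (0.76 log units; beyond the scatter) and so shows that the read-out distinguishes between these two halogens at this position. A single heavy atom changes, with the counts of rings, hydrogen-bond donors and acceptors and the net charge all unchanged, yet the step lies beyond the scatter. Nothing available accounts for this difference.

As far as these compounds go, whether iodo or fluoro at this carbon would go beyond compound 4 or fall back toward compound 3 remains open. So does the outcome of placing a methoxy group or an amine there.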